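A few compounds are considered here, and "the series" means these few. Any claim that something is new, unique, unknown or untested is made for them only; others in the source may bear on it.

Compound 1, `CCC(=O)N1CC2CC(C1)N2`: 190 nM
Compound 2, `CCCC(=O)N1CC2CC(C1)N2`: 350 nM
Compound 3, `O=C([C@H]1C[C@@H]1F)N1CC2CC(C1)N2`: 490 nM

In an assay on CHO cells for displacement of a labelled ligand from Neuronal acetylcholine receptor; alpha3/alpha6/beta2/beta3 (Homo sapiens), read by scintillation counting (on this read-out lower numbers stand for stronger inhibition and higher numbers for weaker inhibition), compound 3 gives the highest of the three numbers; compound 2 lies nearest, and only the gap to compound 1 reaches beyond the scatter. Compound 4, `C[C@@H]1C[C@@H]1C(=O)N1CC2CC(C1)N2`, differs from compound 3 by a group of 4 heavy atoms (4 carbon; one three-membered non-aromatic ring of carbon only) in place of a group of 4 heavy atoms (3 carbon, 1 fluorine; one three-membered non-aromatic ring of carbon only), on a carbonyl carbon. The measured steps that bear on this are the two onto the same carbonyl carbon, a 2.6-fold higher number from compound 1 to compound 3 (0.41 log units; beyond the scatter) and a 1.4-fold higher number from compound 2 to compound 3 (0.15 log units; within the scatter), both modest. Since keeping the three-membered ring and changing only its substituent is a smaller alteration than either of those, no shift beyond the scatter is expected, with a slight lean toward a lower number. Compound 4 is therefore estimated at 350 nM, in the range 150 nM to 800 nM, an expected step of a 1.4-fold lower number from compound 3 to compound 4 (0.15 log units; within the scatter).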

Compound 4, inhibition constant: 92 nM
The estimate for compound 4 lay 3.8-fold (0.58 log units) above the measured number, outside the stated range (below it).
By their numbers in this assay, from the lowest: compound 4; then compounds 1, 2 and 3 (each within the scatter of the next, the first and the last beyond it).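

Among these compounds, on a carbonyl carbon, this position proved more sensitive than the earlier compounds showed: with the three-membered ring kept, exchanging 2-fluorocyclopropyl for the all-carbon ring group gives a 5.3-fold lower number from compound 3 to compound 4 (0.73 log units; beyond the scatter). That group also outperforms both open chains, with a 3.8-fold lower number from compound 2 to compound 4 (0.58 log units; beyond the scatter) and a 2.1-fold lower number from compound 1 to compound 4 (0.31 log units; beyond the scatter), so a three-membered ring here can give a lower number as well as a higher one, and compound 4 is the strongest of the four. Nothing available here explains this shift. Still open, on these data alone, is how a cyclobutyl group or an amine at this place would compare, and whether the opposite arrangement at the two stereocentres of compound 4 would keep its number.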